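This account rests on a few compounds, and the source may have more. Where it says the series, first, only, none or still open, it means among the compounds named here.

Compound 1 `CC(C)N(O)C(=O)NCCSc1nc2ccccc2s1` holds the highest of the two numbers recorded here. In a functional assay for inhibition of Polyunsaturated fatty acid 5-lipoxygenase (Homo sapiens) (on this read-out higher numbers stand for an effect only at larger amounts of compound and lower numbers for an effect already at smaller amounts), compound 1 gives 130 nM, whereas compound 2 `CN(O)C(=O)NCCSc1nc2cc(Cl)ccc2s1` gives 20 nM in this assay; the two differ in more than one place, so their gap cannot be traced to a single change. Compound 3 `CCOc1ccc2nc(SCCNC(=O)N(O)C(C)C)sc2c1` has not yet been measured in this assay. It differs from compound 1 by ethoxy in place of hydrogen on an aromatic carbon, the ethoxy sitting meta to a fused ring and para to a fused ring on the six-membered carbon-only aromatic ring of the shared core. Among the compounds with values here, no measured pair isolates this change. Compound 2 shows that a substituent on that ring can go together with a lower number, yet its hydroxyurea also differs. Compound 3 is thus expected to shift toward a lower number by a modest 1.6-fold lower number from compound 1 to compound 3 (0.21 log units; within the scatter). Compound 3 is estimated at 80 nM, within a range from 25 nM to 250 nM.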

Compound 3, half-maximal effective concentration: 390 nM
Estimate against measurement, compound 3: 4.9-fold (0.69 log units) below, and the stated range ends below it.
By their numbers in this assay, from the lowest: compound 2; then compound 1; then compound 3.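

In this assay, ethoxy in place of hydrogen on this aromatic carbon, meta to a fused ring and para to a fused ring, gives a 3.0-fold higher number from compound 1 to compound 3 (0.48 log units; beyond the scatter). Within the data shown here, this is the first single change on the shared core that can be read on its own, and it shows that a substituent on this ring can go with a higher number, a step beyond the usual scatter. Compound 2 had pointed the other way, but it differs from compound 1 in more than one place. Nothing available here gives a reason for this step.

The compounds shown leave open whether this step belongs to ethoxy in particular or would also appear with another group on the same carbon. A methoxy, a fluorine or an amine there would begin to separate these possibilities.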